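Compound 4: iodo in place of hydrogen on compound 3

The compounds below may be only part of what the source reports. "The series", "measured", "known", "first", "only" and "open" are said of these compounds alone.

Measured so far in a functional assay on MKN-74 cells (Homo sapiens) for antiproliferative activity, with a stated time of 24 h; on this read-out lower numbers stand for stronger inhibition and higher numbers for weaker inhibition:
- compound 1 `NC(=O)c1c(NC(=O)c2ccccc2Cl)sc2c1CCN(Cc1ccccc1F)C2` gives 12900 nM
- compound 2 `NC(=O)c1c(NC(=O)c2ccccc2Cl)sc2c1CCN(Cc1ccc(Cl)cc1Cl)C2` gives 16300 nM
- compound 3 `NC(=O)c1c(NC(=O)c2ccccc2Cl)sc2c1CCN(C(=S)Nc1ccccc1)C2` gives 15600 nM

All three numbers sit close together. Compound 3 holds the second highest of the three; its nearest neighbour is compound 2, with a 1.0-fold lower number from compound 2 to compound 3 (0.02 log units; within the scatter), and the step of a 1.2-fold higher number from compound 1 to compound 3 (0.08 log units; within the scatter) is likewise within the scatter. So far nothing in the series has moved this assay beyond its noise.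

Compound 4 `NC(=O)c1c(NC(=O)c2ccccc2Cl)sc2c1CCN(C(=S)Nc1ccccc1I)C2` is the next member. Relative to compound 3 the change is iodo in place of hydrogen on an aromatic carbon; one bond further out it reads phenyl to 2-iodophenyl, anilino to (2-iodophenyl)amino.

Among the measured compounds shown here, no measured step touches that aromatic ring, so no direct precedent exists. For the measured compounds named here, the only related comparison is a 1.3-fold higher number from compound 1 to compound 2 (0.10 log units; within the scatter), where the halogen pattern on the other aryl group changed and the number stayed within the scatter; the same holds for a 1.2-fold higher number from compound 1 to compound 3 (0.08 log units; within the scatter), where the whole group on the ring nitrogen was exchanged. On that basis no step beyond the scatter is expected for the iodo addition, a 1.0-fold lower number from compound 3 to compound 4 (0.02 log units; within the scatter).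

For compound 4 the estimate in this assay is 15000 nM, with a range from 6000 nM to 40000 nM.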

Compound 4, half-maximal inhibitory concentration: 2630 nM
Compound 4: middle estimate off by 5.7-fold (0.76 log units), on the high side, and the stated range ends above it.
By their numbers in this assay, from the lowest: compound 4; then compounds 1, 3 and 2 (each within the scatter of the next).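

In this assay, among the compounds shown here, this aromatic position is the first place where a single change moves the number beyond the scatter: a 5.9-fold lower number from compound 3 to compound 4 (0.77 log units; beyond the scatter), for iodo in place of hydrogen on an aromatic carbon, ortho to a large group. The exchanges on the ring nitrogen among compound 1, compound 2 and compound 3 all stayed within the scatter, whereas the group carrying 2-iodophenyl stands apart from the other two groups, with a 6.2-fold lower number from compound 2 to compound 4 (0.79 log units; beyond the scatter) and a 4.9-fold lower number from compound 1 to compound 4 (0.69 log units; beyond the scatter), so this part of the molecule does respond in this assay once that ring bears iodo. Nothing at hand bears on why the number falls with this change.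

As far as these compounds go, it remains open whether the step belongs to iodo itself or would also appear with a methyl, methoxy or amine group at this place, and whether iodo elsewhere on the same ring would give it. Also open, from the compounds shown here alone, is whether iodo would carry a similar step on the aryl groups of compound 1 and compound 2.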